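Thiazolidinone amides on HOS-TE85 cells: notes toward compound 4

The source may report more compounds than this note shows. Statements on the series, on what has been measured and on what is new or still open speak of the compounds shown alone.

Measured so far in a functional assay on HOS-TE85 cells (Homo sapiens) for inhibition, read by CCK-8 assay, with a stated time of 72 h; a higher number here means a weaker inhibitor, a lower number a stronger inhibitor:
- compound 1, `O=C(NCCCCn1cccn1)c1cccc(C2SCC(=O)N2c2cc(Br)ccn2)c1`, gives 105 nM
- compound 2, `Cc1cccc(N2C(=O)CSC2c2cccc(C(=O)NCCCCc3ccccc3)c2)c1`, gives 93.2 nM
- compound 3, `COc1ccccc1N1C(=O)CSC1c1cccc(C(=O)NCCCCn2ccc3ccccc32)c1`, gives 286 nM

Compound 2 carries the lowest of the three numbers in this assay. Its gap to compound 1 lies within the scatter, so no order between these two is claimed; its gap to compound 3 lies beyond the scatter, though compound 3 differs from compound 2 in more than one place, so the two values only show that compound 3 gives the higher number.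

Compound 4, `O=C(NCCCCc1ccccc1)c1cccc(C2SCC(=O)N2c2nccs2)c1`, has not been measured. It differs from compound 2 by one change: 1,3-thiazol-2-yl in place of 3-methylphenyl on an amide-type nitrogen in a ring. For the measured compounds named here, compound 1 shows that a six-membered aromatic ring with a nitrogen in this position keeps the number close to that of compound 2 in this assay, which is the only guide to a ring change at this nitrogen. Going by the values given here, no single-point step between measured compounds exists, so the expected size of the step for compound 4 in this assay is small, in either direction, and likely none beyond the scatter.

For compound 4 the estimate is 130 nM, within 50 nM to 350 nM, meaning an expected step of a 1.4-fold higher number from compound 2 to compound 4 (0.14 log units; within the scatter).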

Compound 4, half-maximal inhibitory concentration: > 1000 nM
Compound 4: only a limit was reported (the forecaster's own chance of this, stated with the estimate: 5%); middle value at least 7.6-fold (0.88 log units) from the limit.
By their numbers in this assay, from the lowest: compounds 2 and 1 (each within the scatter of the next); then compound 3. At a limit, above all of these: compound 4.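

In this assay, for the compounds shown here, placing 1,3-thiazol-2-yl in place of 3-methylphenyl on an amide-type nitrogen in a ring gives an at least 10-fold higher number from compound 2 to compound 4 (1.03 log units; beyond the scatter), the first step that can be read at a single place. For compound 4, the value of > 1000 nM is a limit and not a number: the limit of > 1000 nM in this assay, at which 1 of the 4 values shown sits. The nitrogen substituent is therefore not interchangeable among aromatic rings, as this one exchange, with the rest of compound 2 unchanged, moves the number beyond the scatter.

The compounds shown leave open which feature of 1,3-thiazol-2-yl goes with this step, whether the five-membered ring, the ring nitrogen or the ring sulfur, and a single step cannot separate these or give a cause. Also open, going by these compounds, is how an unsubstituted phenyl, a thiophen-2-yl or a pyridin-2-yl on this nitrogen, with the rest of compound 2 kept, would read in this assay.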